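The source may hold more compounds than are shown below. What is called first, only, known or untested is meant among the compounds shown, and "the series" means these compounds.

Working notes on the series. Three compounds have numbers in an in vitro functional assay on SH-SY5Y cells for agonist activity at Neuronal acetylcholine receptor; alpha3/beta4 (Homo sapiens), read by FLIPR and calcium flux; a higher number here means a larger maximal response, a lower number a smaller maximal response. Compound 1, `Clc1ccncc1C1=CC2CNCC(C1)C2`, gives 105% there. Compound 2, `C1=C(c2ccc(-c3ccccc3)nc2)CC2CNCC1C2`, gives 17% in this assay. Compound 3, `C1=C(c2cccnc2)C[C@H]2CNC[C@@H]1C2`, gives 142% in this assay, the highest of the three numbers; its nearest neighbour is compound 1, lower by a margin beyond the scatter, and compound 2 lies furthest below it, also beyond the scatter. Among the measured compounds shown here, compounds 1 and 2 are drawn without defined stereocentres, so no measured pair shows what inverting the configuration does.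

Compound 4, `C1=C(c2cccnc2)C[C@@H]2CNC[C@H]1C2`, is yet to be measured in this assay. It relates to compound 3 as follows: the two compounds have the same atoms and bonds and differ only in configuration as drawn: 2 of 2 stereo elements differ (all stereocentres are inverted: mirror images); a stereocentre at a saturated ring carbon is drawn S in compound 3 and R in compound 4; a stereocentre at a saturated ring carbon is drawn R in compound 3 and S in compound 4. For the measured compounds named here, since compound 3 carries a defined configuration and gives 142%, while no stereo pair is available, the step is expected to go downward, possibly beyond the scatter, with wide uncertainty. For compound 4 the estimated value in this assay is 100%, within 30% to 160%, which means an expected step of a number 42 percentage points lower from compound 3 to compound 4 (beyond the scatter).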

Compound 4, largest response reached (reported as percent of maximum), in percent of the reference or control that the assay uses: 139%
The estimate for compound 4 lay 39 percentage points below the measured number; the range from low to high includes it.
By their numbers in this assay, from the lowest: compound 2; then compound 1; then compounds 4 and 3 (each within the scatter of the next).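

The pair gives the series its first direct reading of configuration, and that reading is clean for one reason: the fact that compounds 3 and 4 differ only in the configuration as drawn. In this assay, inverting both stereocentres gives a number 3 percentage points lower from compound 3 to compound 4 (within the scatter), so the largest response does not separate these mirror images. Configuration at these two saturated ring carbons therefore shows no measurable effect on this read-out for this pair, though the finding extends to no other compound in the series.

As far as these compounds go, whether the mirror images would stay this close with a methoxy group or a nitrile on the shared core remains open. Also open, from the compounds shown here alone, is whether they differ in the concentration needed to reach that response, a question that a maximal response alone cannot answer.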